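The source may report more compounds than this note shows. Statements on the series, on what has been measured and on what is new or still open speak of the compounds shown alone.

Compound 1 `Cn1cc(C2=C(c3nn(CCn4ccnc4)c4ncccc34)C(=O)NC2=O)c2ccccc21`: > 100000 nM. Compound 2 `Cn1cc(C2=C(c3nn(CCCN4CCCCC4)c4ncccc34)C(=O)N(c3ccc(Cl)cc3)C2=O)c2ccccc21`: 1800 nM.

In a functional assay on K562 cells (Homo sapiens) for antiproliferative activity, read by MTT assay, with a stated time of 48 h (a higher number here means a weaker inhibitor, a lower number a stronger inhibitor), compound 1 reaches only a limit, > 100000 nM, so no number is known for it. In this assay, going by the values given here, compound 2 gives 1800 nM; as it differs from compound 1 in more than one place, the two values show only that the pair differ. The unmeasured compound 3 `Cn1cc(C2=C(c3nn(CCCn4cncn4)c4ncccc34)C(=O)NC2=O)c2ccccc21` carries (1H-1,2,4-triazol-1-yl)methyl in place of 1H-imidazol-1-yl on a saturated chain carbon, two bonds along the chain from an aromatic nitrogen. Among the compounds with values here, no measured step bears on this change, so no step beyond the scatter is expected in either direction. Compound 3 is expected to give about 100000 nM, between 30000 nM and 300000 nM. The step of a number no higher from compound 1 to compound 3 (the limit leaves the size open) is expected to stay within the scatter.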

Compound 3, half-maximal inhibitory concentration: > 100000 nM
Compound 3: no number, only a limit; the forecaster's own chance of this, stated with the estimate: 70%; the middle value sits exactly at the limit.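

Compound 1 and compound 3 both reach only a limit, so no step between them can be read: the limit of > 100000 nM in this assay, at which 2 of the 3 values shown sit.

From the compounds shown here alone, whether (1H-1,2,4-triazol-1-yl)methyl in place of 1H-imidazol-1-yl changes antiproliferative activity at all remains open.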